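The source may report more compounds than this note shows. Statements on the series, on what has been measured and on what is new or still open speak of the compounds shown alone.

Measured in a functional assay on A2780 cells (Homo sapiens) for antiproliferative activity, read by MTT assay, with a stated time of 48 h; on this read-out lower numbers stand for stronger inhibition and higher numbers for weaker inhibition:
Compound 1 `COc1ccc(C(=O)c2ccc(OC)c3c2OC(C)(C)C=C3)c(NC(=O)CN)c1`: 380 nM
Compound 2 `CCNCC(=O)Nc1cc(OC)ccc1C(=O)c1ccc(OC)c2c1OC(C)(C)C=C2`: 1980 nM

For the measured compounds named here, compound 2 holds the higher of the two numbers, and compound 1 is its only neighbour. Compound 3 `COc1ccc(C(=O)c2ccc(OC)c3c2OC(C)(C)C=C3)c(NC(=O)CN(C)C)c1` follows from compound 2 by dimethylamino in place of ethylamino on a saturated chain carbon bound to a carbonyl carbon. Going by the values given here, the only measured step bearing on this is a 5.2-fold higher number from compound 1 to compound 2 (0.72 log units; beyond the scatter), with ethyl in place of hydrogen on an amine nitrogen. That step was modest, and it does not cover an exchange between two substituted amines. The expected change is small, at most a slight drop, and within the scatter: a 1.4-fold lower number from compound 2 to compound 3 (0.15 log units; within the scatter). Compound 3 is estimated at 1400 nM, with an expected range of 500 nM to 4000 nM.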

Compound 3, half-maximal inhibitory concentration: 790 nM
Beside the measured number, compound 3's estimate is 1.8-fold (0.25 log units) above it; measured number inside the range.
By their numbers in this assay, from the lowest: compound 1; then compound 3; then compound 2.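

In this assay, this position responds even to an exchange that leaves the heavy-atom count unchanged: dimethylamino in place of ethylamino gives a 2.5-fold lower number from compound 2 to compound 3 (0.40 log units; beyond the scatter). Dimethylamino does not match plain amino, however, with a 2.1-fold higher number from compound 1 to compound 3 (0.32 log units; beyond the scatter), so amino retains the lowest number of the three. Nothing available explains this order of the amines.

Open, going by these compounds, is where methylamino, diethylamino or a ring amine such as pyrrolidine would fall in this order. Also open, on these data alone, is whether a longer chain between the carbonyl and the amine would preserve it.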